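The source may hold more compounds than are shown below. What is called first, only, known or untested is meant among the compounds shown, and "the series" means these compounds.

Measured so far:
compound 1 `Cc1cc(C)c(-c2nc3ccccc3[nH]2)cc1NC(=O)c1ccc(OCc2ccccn2)cc1` with 30 mL.min-1.g-1 in an ADME assay on microsomes from liver (Homo sapiens) for metabolic stability; a higher number here means faster removal of the compound, a lower number slower removal
compound 2 `Cc1csc(-c2cc(NC(=O)c3ccc(OCc4ccccn4)cc3)c(C)cc2C)n1` with 513 mL.min-1.g-1 in this assay

For the measured compounds named here, compound 2 stands at the higher of the two numbers seen so far in this assay; its only neighbour is compound 1, and the step between them, a 17-fold higher number from compound 1 to compound 2 (1.23 log units; beyond the scatter), is the sole measured step. Compound 3 `Cc1cc(C)c(-c2c[nH]nc2C)cc1NC(=O)c1ccc(OCc2ccccn2)cc1` has not yet been measured in this assay. It differs from compound 2 in one place: 3-methyl-1H-pyrazol-4-yl in place of 4-methyl-1,3-thiazol-2-yl on an aromatic carbon. Going by the values given here, the one measured step that bears on this change is a 17-fold higher number from compound 1 to compound 2 (1.23 log units; beyond the scatter), which exchanged a five-membered ring bearing a hydrogen-bond donor for one without. The change from compound 2 to compound 3 again exchanges one such ring, this time bringing a hydrogen-bond donor back in. Among the compounds with values here, on that basis a step downward in this assay is expected for compound 3, though with little certainty about its size, since only one step is known. The expected step is a 4.3-fold lower number from compound 2 to compound 3 (0.63 log units; beyond the scatter). Compound 3 is therefore estimated at 120 mL.min-1.g-1 in this assay, with a range from 35 mL.min-1.g-1 to 400 mL.min-1.g-1.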

Compound 3, intrinsic clearance in microsomes: 20 mL.min-1.g-1
Estimate against measurement, compound 3: 6.0-fold (0.78 log units) above; the whole stated range lies above it.
By their numbers in this assay, from the lowest: compounds 3 and 1 (each within the scatter of the next); then compound 2.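

In this assay, the exchange a 26-fold lower number from compound 2 to compound 3 (1.41 log units; beyond the scatter) keeps the five-membered aromatic ring with 2 hetero atoms, the methyl group and the count of 6 heavy atoms, so a large step arises here without any change in those counted features. What differs is that sulfur gives way to a second nitrogen and a hydrogen-bond donor enters, while the step of a 1.5-fold lower number from compound 1 to compound 3 (0.18 log units; within the scatter) places the two donor-bearing groups level with each other despite their different ring systems. Across these three compounds, compound 2 alone lacks a donor at this position and stands apart in this assay, with no compound going against that pattern, although no measured information explains the difference.

The compounds shown do not separate the loss of sulfur from the gain of the donor, since both happen together in the step to compound 3; a 1,3-oxazol-2-yl group, or a 3-methylpyrazol-4-yl group with a methyl group in place of the ring nitrogen's hydrogen, would pull the two apart. From the compounds shown here alone, whether the pattern would hold for an amine at this position also remains open.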